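A few compounds are considered here, and "the series" means these few. Any claim that something is new, unique, unknown or untested is made for them only; others in the source may bear on it.

Measured so far in a functional assay on MCF7 cells (Homo sapiens) for cytotoxicity, read by MTT assay, with a stated time of 48 h; on this read-out lower numbers stand for stronger inhibition and higher numbers for weaker inhibition:
compound 1 `CCN(CC)c1ccc2cc(C(=O)c3ccc(N4CCN(C(=O)CN5CCNCC5)CC4)cc3)oc2c1` — 5340 nM
compound 2 `CCN(CC)c1ccc2cc(C(=O)c3ccc(N4CCN(C(=O)CN5CCN(C(=O)/C=C/c6ccccc6)CC5)CC4)cc3)oc2c1` — 13400 nM
compound 3 `CCN(CC)c1ccc2cc(C(=O)c3ccc(N4CCN(C(=O)CN5CCN(S(=O)(=O)c6ccc(F)cc6)CC5)CC4)cc3)oc2c1` — 20500 nM

Of these three, compound 3 stands at the highest number; the step of a 3.8-fold higher number from compound 1 to compound 3 (0.58 log units; beyond the scatter) lies beyond the scatter, whereas a 1.5-fold higher number from compound 2 to compound 3 (0.18 log units; within the scatter) does not. Compound 4 `C#CCN1CCN(CC(=O)N2CCN(c3ccc(C(=O)c4cc5ccc(N(CC)CC)cc5o4)cc3)CC2)CC1` differs from compound 3 by propargyl in place of (4-fluorophenyl)sulfonyl on an amine nitrogen in a ring. Going by the values given here, the steps that bear on this change are a 3.8-fold higher number from compound 1 to compound 3 (0.58 log units; beyond the scatter) and a 2.5-fold higher number from compound 1 to compound 2 (0.40 log units; beyond the scatter): each time a hydrogen on that ring nitrogen was exchanged for a larger group, the number rose. Taking the (4-fluorophenyl)sulfonyl group away again and putting in the small propargyl chain is therefore expected to lower the number, roughly undoing the earlier rise, because a 3.8-fold higher number from compound 1 to compound 3 (0.58 log units; beyond the scatter) went the other way. Compound 4 is expected to give 6000 nM, with a range from 2500 nM to 15000 nM. That corresponds to an expected step of a 3.4-fold lower number from compound 3 to compound 4 (0.53 log units; beyond the scatter).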

Compound 4, half-maximal inhibitory concentration: > 40000 nM
Compound 4: a limit, no number (the forecaster's own chance of this, stated with the estimate: 5%); middle value at least 6.6-fold (0.82 log units) from the limit.
By their numbers in this assay, from the lowest: compound 1; then compounds 2 and 3 (each within the scatter of the next). At a limit, above all of these: compound 4.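

In this assay, compound 4 gives a limit, not a number: the limit of > 40000 nM in this assay, at which 1 of the 4 values shown sits. A propargyl chain on this ring nitrogen does not return the number to that of the unsubstituted amine, as shown by an at least 7.4-fold higher number from compound 1 to compound 4 (0.87 log units; beyond the scatter), so having fewer heavy atoms than the earlier groups does not by itself lower the number. The step of an at least 2.9-fold higher number from compound 2 to compound 4 (0.47 log units; beyond the scatter) also clears the scatter, whereas an at least 1.9-fold higher number from compound 3 to compound 4 (0.29 log units; that floor lies within the scatter) has a floor within it, so compound 4 is not clearly separated from compound 3.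

Still open, on these data alone, is whether the triple bond matters, which a saturated propyl chain or a methyl group on this nitrogen could help to show.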